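Phenyl to Fluoro: Carrying One Change onto a Second Core

The source may hold more compounds than are shown below. What is called first, only, known or untested is meant among the compounds shown, and "the series" means these compounds.

Compound 1 `N#Cc1ccc(NC(=O)c2cc(-c3ccccc3)ccc2O)cc1` gives 1350 nM in a functional assay on HL-60 cells (Homo sapiens) for cytotoxicity, read by luminescence and CellTiter-Glo, with a stated time of 3 days; a lower number here means a stronger inhibitor, a higher number a weaker inhibitor.
Compound 2 `O=C(Nc1cc(C(F)(F)F)cc(C(F)(F)F)c1)c1cc(Br)c(-c2ccccc2)cc1O` gives 430 nM in this assay.
Compound 3 `N#Cc1ccc(NC(=O)c2cc(F)ccc2O)cc1` gives 1420 nM in this assay.

Compound 4 `O=C(Nc1cc(C(F)(F)F)cc(C(F)(F)F)c1)c1cc(Br)c(F)cc1O` has not been measured. Compound 3 arises from compound 1 by fluoro in place of phenyl on an aromatic carbon, a change that produced a 1.1-fold higher number from compound 1 to compound 3 (0.02 log units; within the scatter). Compound 4 arises from compound 2 by fluoro in place of phenyl on an aromatic carbon. The difference between the two cores is not broken down here. The surroundings of the place differ: in compound 1 the place is meta to a large group and para to a hydroxy group, whereas in compound 2 it is ortho to a bromo group, meta to a hydroxy group and para to a large group, so the two changes are the same kind of change, not the same. Compound 2 has the lowest number of the three, and its steps to compound 1 and compound 3 lie beyond the scatter. Compound 4 is therefore expected to show a 1.1-fold higher number from compound 2 to compound 4 (0.04 log units; within the scatter), because the earlier step of a 1.1-fold higher number from compound 1 to compound 3 (0.02 log units; within the scatter) stayed within the scatter. The estimate for compound 4 is 470 nM, with a likely range from 200 nM to 1100 nM.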

Compound 4, half-maximal inhibitory concentration: 250 nM
Compound 4: middle estimate off by 1.9-fold (0.27 log units), on the high side, within the range that was stated.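

Putting fluoro in place of phenyl on the core of compound 2 gives a 1.7-fold lower number from compound 2 to compound 4 (0.24 log units; within the scatter) in this assay, so this step, like the earlier one, cannot be told apart from repeat-measurement noise. Set side by side, the two steps agree: the same change on two cores in this assay, a 1.1-fold higher number (0.02 log units; within the scatter) from compound 1 to compound 3 and a 1.7-fold lower number (0.24 log units; within the scatter) from compound 2 to compound 4, 1.8-fold (0.26 log units) apart, within the scatter of two such steps

In these two pairs, then, the swap carries from one core to the other with the same outcome, but two pairs cannot show that it would do so on any further core, and they say nothing about why the large phenyl group and the single fluoro atom read alike here. Going by these compounds, it remains open whether a smaller or differently built group at this place, such as a methoxy group, an amine or a carboxylic acid, would also leave the number within the scatter. Also open, on these data alone, is whether the same holds on a core carrying neither the nitrile nor the trifluoromethyl groups.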